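This account rests on a few compounds, and the source may have more. Where it says the series, first, only, none or still open, it means among the compounds named here.

Compound 2 `O=c1c(-c2ccc(O)cc2)coc2cc(OCc3ccc(F)cc3)cc(O)c12` stands at the top of an ADME assay on C8166 cells (Homo sapiens) for inhibition, read by MTT assay, with a stated time of 72 h (a lower number here means that less compound is tolerated, a higher number that more compound is tolerated), where compound 2 reaches > 200 ug/mL as a limit rather than a number (the limit of > 200 ug/mL in this assay, at which 1 of the 2 values shown sits). For the measured compounds named here, compound 1 `O=C1C[C@@H](c2ccc(O)cc2)Oc2cc(OCc3ccc(F)cc3)cc(O)c21` gives 11.5 ug/mL in this assay, but no step between these two compounds is measured. Compound 3 `CC(C)(C)Oc1cc(O)c2c(=O)c(-c3ccc(O)cc3)coc2c1` differs from compound 2 by tert-butyl in place of 4-fluorobenzyl on an oxygen on an aromatic ring. Going by the values given here, with no measured step to draw on, compound 3 is expected to remain near the limit, so that the step of an at least 1.1-fold lower number from compound 2 to compound 3 (0.04 log units; that floor lies within the scatter) is expected to lie within the scatter or to turn only modestly downward. Compound 3 is therefore estimated at 180 ug/mL, within a range from 60 ug/mL to 400 ug/mL.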

Compound 3, half-maximal cytotoxic concentration: 47.7 ug/mL
Estimate against measurement, compound 3: 3.8-fold (0.58 log units) above, outside the stated range (below it).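

In this assay, tert-butyl in place of 4-fluorobenzyl on this oxygen gives an at least 4.1-fold lower number from compound 2 to compound 3 (0.62 log units; beyond the scatter). For the compounds shown here, this is the first measured step at this position and shows that the group carried there matters for how much compound the cells tolerate. Its full size cannot be read, since the value of compound 2 is a limit: the limit of > 200 ug/mL in this assay, at which 1 of the 3 values shown sits.

As far as these compounds go, whether a plain benzyl, a methyl or a chain ending in an amine on this oxygen would stand nearer compound 2 or compound 3 remains open. So does whether the same change would act alike on the core of compound 1.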